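Swapping the Para Substituent for Methylsulfanyl

This account rests on a few compounds, and the source may have more. Where it says the series, first, only, none or still open, it means among the compounds named here.

Three close relatives of one amide-linked coumarin-type core have been tested in an in vitro assay on BTI-TN-5B1-4 cells for inhibition of Amine oxidase [flavin-containing] A (Homo sapiens), read by fluorescence; on this read-out higher numbers stand for weaker inhibition and lower numbers for stronger inhibition. Compound 1 `Cc1ccc(NC(=O)c2cc3ccccc3oc2=O)cc1` carries a methyl group on the outer ring and gives 19500 nM. Compound 2 `CCc1ccc(NC(=O)c2cc3ccccc3oc2=O)cc1` carries an ethyl group in that spot and gives 15700 nM. Compound 3 `CCOC(=O)c1ccc(NC(=O)c2cc3ccccc3oc2=O)cc1` carries an ethoxycarbonyl group there and gives 16000 nM. The recorded steps are all small: a 1.2-fold lower number from compound 1 to compound 2 (0.09 log units; within the scatter), a 1.2-fold lower number from compound 1 to compound 3 (0.09 log units; within the scatter) and a 1.0-fold higher number from compound 2 to compound 3 (0.01 log units; within the scatter). Compound 3 therefore sits among the others inside the usual scatter, and none of the three can be called stronger or weaker than another.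

Compound 4 `CSc1ccc(NC(=O)c2cc3ccccc3oc2=O)cc1` has not yet been measured. It differs from compound 3 in one place: methylsulfanyl in place of ethoxycarbonyl on an aromatic carbon. For the measured compounds named here, the steps that bear on this are those just given, since each of them also changes only the group on that same aromatic carbon, and each stayed within the scatter. Three different groups at that position, a small alkyl, a larger alkyl and an ester, all landed in the same narrow band, so the expectation for this assay is no step beyond the scatter, that is roughly no change at the digits printed from compound 3 to compound 4 (within the scatter). Compound 4 is accordingly estimated at 16000 nM, with a plausible range from 7000 nM to 36000 nM.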

Compound 4, half-maximal inhibitory concentration: 14800 nM
For compound 4 the middle estimate is 1.1-fold (0.03 log units) above the measured one; the range from low to high includes it.
By their numbers in this assay, from the lowest: compounds 4, 2, 3 and 1 (each within the scatter of the next).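

In this assay the new group gives the same picture as the earlier ones, with a 1.1-fold lower number from compound 3 to compound 4 (0.03 log units; within the scatter) and a 1.1-fold lower number from compound 2 to compound 4 (0.03 log units; within the scatter) and also a 1.3-fold lower number from compound 1 to compound 4 (0.12 log units; within the scatter) as the steps to the three earlier compounds. For the compounds shown here, what compound 4 adds is a group containing sulfur on this aromatic carbon, where the earlier compounds had only carbon or carbon and oxygen, and a change in size as well, since an ethoxycarbonyl of 5 heavy atoms leaves and a methylsulfanyl of 2 heavy atoms enters without the number moving beyond the scatter. No measurement in hand offers an explanation for why the number stays so flat across these groups.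

Still open, as far as these compounds go, is whether a group of another kind on this aromatic carbon, such as an amine, a carboxylic acid or a much longer chain, would move the number beyond the scatter. From the compounds shown here alone, all four compounds also share the same core and amide link, so whether this flat picture would survive a change elsewhere in the molecule remains unknown.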